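A few compounds are considered here, and "the series" means these few. Any claim that something is new, unique, unknown or untested is made for them only; others in the source may bear on it.

Compound 1 `CC(C)(C(=O)N1CCC(CC(=O)O)CC1)C(CCc1ccccc1)NC(=O)c1ccc(C(=N)N)cc1` gives 0.767 h
Compound 2 `CC(C)(C(=O)N1CCC(CC(=O)O)CC1)C(NC(=O)c1ccc(C(=N)N)cc1)c1cccc(Cl)c1` gives 2.5 h

These numbers come from an in vivo ADME assay on the whole organism (Cavia porcellus) (a lower number here means that the compound disappears faster, a higher number that the compound lasts longer), where compound 2 holds the higher of the two at 2.5 h and lasts longer than compound 1 by a margin beyond the usual scatter. The next molecule, compound 3 `CC(C)(C(=O)N1CCC(CC(=O)O)CC1)C(NC(=O)c1ccc(C(=N)N)cc1)c1cccc(O)c1` has not yet been measured. It differs from compound 2 by a single swap, hydroxy in place of chloro on an aromatic carbon and the rest of the structure stays the same.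

For the measured compounds named here, only one measured step bears on this change, a 3.3-fold higher number from compound 1 to compound 2 (0.51 log units; beyond the scatter) which came with 3-chlorophenyl in place of phenethyl. That modest step shows that changing this part of the molecule can shift the half-life. Going by the values given here, no measured pair swaps chloro for hydroxy, so the step is only a rough guide to size, and the downward direction is a judgement rather than a measured trend. A modest drop is expected, and the estimated change is a 2.1-fold lower number from compound 2 to compound 3 (0.32 log units; beyond the scatter) with wide uncertainty on either side. Compound 3 is estimated at 1.2 h with an expected range from 0.5 h to 3 h in this assay once it is tested.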

Compound 3, half-life: 1.08 h
Estimate against measurement, compound 3: 1.1-fold (0.05 log units) above, and the stated range covers the measured number.
By their numbers in this assay, from the lowest: compounds 1 and 3 (each within the scatter of the next); then compound 2.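

In this assay, exchanging one atom on the six-membered aromatic ring, 3-chlorophenyl to 3-hydroxyphenyl, gives a 2.3-fold lower number from compound 2 to compound 3 (0.36 log units; beyond the scatter), which shows that the half-life responds to the group on this ring and not only to the larger swap away from phenethyl. Replacing phenethyl with 3-hydroxyphenyl gives a 1.4-fold higher number from compound 1 to compound 3 (0.15 log units; within the scatter), so an aromatic ring at this chain carbon does not by itself bring a longer half-life; among these compounds, the clear gain appears only with chloro on the ring. No accompanying measurement shows what lies behind these shifts.

Going by these compounds, with only chloro and hydroxy compared on this ring, it remains open whether the half-life of compound 2 is particular to chloro or would also be reached with a fluoro, methyl, methoxy or amine group in the same place. It is also unknown how the half-life would respond if chloro or hydroxy stood elsewhere on the ring, or if the ring carried more than one such group.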